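A few compounds are considered here, and "the series" means these few. Any claim that something is new, unique, unknown or untested is made for them only; others in the source may bear on it.

Of the compounds shown here, three sharing one core have been measured in a functional assay on HCT-15 cells (Homo sapiens) for cytotoxicity; a lower number here means a stronger inhibitor, a higher number a weaker inhibitor. Compound 1 `Cc1ccc(-c2cc3cc(C)ccc3c(O)n2)cc1` gives 35500 nM, compound 2 `COc1ccc(-c2cc3cc(C)ccc3c(N3CCN(C)CC3)n2)cc1` gives 9330 nM, and compound 3 `Cc1ccc2c(N3CCN(C)CC3)nc(-c3ccc(Cl)cc3)cc2c1` gives 6030 nM. Compound 3 therefore has the lowest number of the three, although its value lies within the scatter of that of compound 2. The value of compound 1 stands clearly higher, beyond the scatter of compound 3.

The next compound to be measured is compound 4 `Cc1ccc(-c2cc3cc(C)ccc3c(N3CCN(C)CC3)n2)cc1`. It differs from compound 3 by methyl in place of chloro on an aromatic carbon, para to a large group, so that 4-chlorophenyl becomes 4-methylphenyl: methyl in place of chloro on an aromatic carbon.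

Within the data shown here, one measured step bears directly on this change. Chloro in place of methoxy at that same place gave a 1.5-fold lower number from compound 2 to compound 3 (0.19 log units; within the scatter), so that exchange did not move the number beyond the scatter. Among the measured compounds shown here, compound 1 differs from compound 2 and compound 3 in more than the aromatic substituent, so it offers no comparable step. A single small step is thin evidence, but it gives no reason to expect a large shift in this assay here.

The expected result is a 1.2-fold higher number from compound 3 to compound 4 (0.09 log units; within the scatter), a step that would stay within the scatter. For compound 4 the estimated value is 7500 nM, with an expected range from 3500 nM to 16000 nM.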

Compound 4, half-maximal inhibitory concentration: 8320 nM
Estimate against measurement, compound 4: 1.1-fold (0.05 log units) below; measured number inside the range.
By their numbers in this assay, from the lowest: compounds 3, 4 and 2 (each within the scatter of the next); then compound 1.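

With compound 4, the place para to a large group on the six-membered aromatic ring of carbon only now carries chloro, methoxy or methyl, and in this assay the new steps show a 1.4-fold higher number from compound 3 to compound 4 (0.14 log units; within the scatter) and a 1.1-fold lower number from compound 2 to compound 4 (0.05 log units; within the scatter). Taken together with the earlier step, these exchanges leave all three groups within the scatter of one another, so this small set gives no separation at this place. Compound 4 also provides the first single-place comparison with the hydroxy compound, a 4.3-fold lower number from compound 1 to compound 4 (0.63 log units; beyond the scatter), the only step among those shown that lies beyond the scatter, and it arises from 4-methylpiperazin-1-yl in place of hydroxy on an aromatic carbon rather than from any change at the para place; no supporting data are available to explain these results.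

The compounds shown leave open whether a group of another kind at the para place, such as an amine, a carboxylic acid or a longer alkyl chain, would move the number beyond the scatter. They also leave open how other amines, such as morpholine or piperidine, would compare with 4-methylpiperazin-1-yl.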